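Methyl in Place of Chloro: What to Expect

A few compounds are considered here, and "the series" means these few. Any claim that something is new, unique, unknown or untested is made for them only; others in the source may bear on it.

Compound 1 `Cc1ccc(C2=NN(C(N)=S)C(c3ccc(Cl)cc3)C2)cc1` was tested in an assay on mitochondria for inhibition of Amine oxidase [flavin-containing] B (Bos taurus) (a higher number here means a weaker inhibitor, a lower number a stronger inhibitor), where compound 1 gives 15 nM, the highest of the three numbers seen so far. In this assay compound 2 `Cc1ccc(C2=NN(C(N)=S)[C@@H](c3ccc(Cl)cc3)C2)cc1` gives 2.7 nM, and compound 3 `Cc1ccc(C2=NN(C(N)=S)[C@H](c3ccc(Cl)cc3)C2)cc1` gives 1 nM. All three share every atom and bond; what sets them apart is that compound 1 is drawn without a defined configuration at the saturated ring carbon, whereas compound 2 and compound 3 are drawn with opposite configurations there the fact that one of compounds 1 and 2 is drawn with a defined configuration and the other without, at the place where they differ the fact that one of compounds 1 and 3 is drawn with a defined configuration and the other without, at the place where they differ (the fact that compounds 2 and 3 differ only in the configuration as drawn). The measured steps are a 5.6-fold lower number from compound 1 to compound 2 (0.74 log units; beyond the scatter), a 15-fold lower number from compound 1 to compound 3 (1.18 log units; beyond the scatter) and a 2.7-fold lower number from compound 2 to compound 3 (0.43 log units; beyond the scatter).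

Compound 4 `Cc1ccc(C2=NN(C(N)=S)C(c3ccc(C)cc3)C2)cc1` differs from compound 1 by methyl in place of chloro on an aromatic carbon. Within the data shown here, none of the measured steps alters a ring substituent, so none bears directly on this exchange; they speak only to configuration. With no direct guide, the expected step is a 2.3-fold higher number from compound 1 to compound 4 (0.37 log units; beyond the scatter), a modest change beyond the scatter toward a higher number. Compound 4 is therefore estimated at about 35 nM, with a plausible range from 8 nM to 150 nM.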

Compound 4, inhibition constant: 10 nM
The estimate for compound 4 lay 3.5-fold (0.54 log units) above the measured number; the measured number falls inside the stated range.
By their numbers in this assay, from the lowest: compound 3; then compound 2; then compounds 4 and 1 (each within the scatter of the next).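

Going from 4-chlorophenyl to 4-methylphenyl gives, in this assay, a 1.5-fold lower number from compound 1 to compound 4 (0.18 log units; within the scatter), so at this position the two groups cannot be told apart. Among these compounds, this is the first measured step that alters a ring substituent rather than configuration, and both compounds are drawn without a defined configuration at the saturated ring carbon, so chloro is not needed here to keep a number of this size. Among the compounds shown here, nothing measured so far explains why the exchange leaves the number within the scatter.

From the compounds shown here alone, whether the two configurations of compound 4 would separate as compound 2 and compound 3 do remains open. So does what an amine, a carboxylic acid or a longer chain at this same place would do to the number.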